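Removing One Methyl Group from a Chloropyridine Carbonyl

The source may hold more compounds than are shown below. What is called first, only, known or untested is meant among the compounds shown, and "the series" means these compounds.

Compound 1 `COc1ccc(C2=NN(C(=O)c3ccc(C)nc3Cl)C(c3ccc(Br)cc3)C2)cc1` serves as the starting point. In a functional assay on WM 266-4 cells (Homo sapiens) for antiproliferative activity, read by MTT assay, with a stated time of 24 h (a lower number here means a stronger inhibitor of growth, a higher number a weaker inhibitor of growth), compound 1 gives 8470 nM. Compound 2 `COc1ccc(C2=NN(C(=O)c3cccnc3Cl)C(c3ccc(Br)cc3)C2)cc1` differs from it only by hydrogen in place of methyl on an aromatic carbon. In this assay compound 2 gives 3050 nM, which corresponds to a 2.8-fold lower number from compound 1 to compound 2 (0.44 log units; beyond the scatter). Compound 3 `COc1ccc(C2=NN(C(=O)c3ccc(C)nc3Cl)C(c3ccc(OCc4ccccc4)cc3)C2)cc1` keeps the methyl but changes the other end of the molecule, (benzyloxy in place of bromo on an aromatic carbon). In this assay compound 3 gives 10500 nM, with a 1.2-fold higher number from compound 1 to compound 3 (0.09 log units; within the scatter), so this exchange leaves the growth inhibition essentially unchanged.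

Compound 4 `COc1ccc(C2=NN(C(=O)c3cccnc3Cl)C(c3ccc(OCc4ccccc4)cc3)C2)cc1` has not yet been measured. It differs from compound 3 by hydrogen in place of methyl on an aromatic carbon, the same change that was made from compound 1 to compound 2, here on the core that carries the benzyloxy group rather than the bromo group. Among the compounds with values here, because the one measured example of this change gave a 2.8-fold lower number from compound 1 to compound 2 (0.44 log units; beyond the scatter), and because the benzyloxy exchange itself gave only a 1.2-fold higher number from compound 1 to compound 3 (0.09 log units; within the scatter), the step from compound 3 to compound 4 is expected to be about a 2.8-fold lower number from compound 3 to compound 4 (0.44 log units; beyond the scatter). Compound 4 is therefore estimated at 3800 nM in this assay, most likely between 1500 nM and 9500 nM.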

Compound 4, concentration for 50% growth inhibition: 9150 nM
Compound 4: middle estimate off by 2.4-fold (0.38 log units), on the low side, and the stated range covers the measured number.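

Taking the methyl off the 2-chloro-6-methylpyridin-3-yl group on the benzyloxy core gives a 1.1-fold lower number from compound 3 to compound 4 (0.06 log units; within the scatter) in this assay, and set beside the earlier case on the bromo core, this result does not clearly differ from it: the same change on two cores in this assay, a 2.8-fold lower number (0.44 log units; beyond the scatter) from compound 1 to compound 2 and a 1.1-fold lower number (0.06 log units; within the scatter) from compound 3 to compound 4, 2.4-fold (0.38 log units) apart, within the scatter of two such steps. Exchanging bromo for benzyloxy on the core without the methyl gives a 3.0-fold higher number from compound 2 to compound 4 (0.48 log units; beyond the scatter), and this step also stays close to its earlier counterpart: the same change on two cores in this assay, a 1.2-fold higher number (0.09 log units; within the scatter) from compound 1 to compound 3 and a 3.0-fold higher number (0.48 log units; beyond the scatter) from compound 2 to compound 4, 2.4-fold (0.38 log units) apart, within the scatter of two such steps. Within the data shown here, these four compounds therefore give no firm sign that either change behaves differently from one core to the other, but they do not show that either change carries over reliably, as each has only two examples, one beyond the scatter and one within it.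

The compounds shown leave open what an ethyl group or an amine would do in place of the methyl on the pyridine ring. They also leave open whether a longer chain or a carboxylic acid in place of the bromo or benzyloxy group would shift growth inhibition further.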